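The source may hold more compounds than are shown below. What is called first, only, known or untested is meant among the compounds shown, and "the series" means these compounds.

Measured in an ADME assay (liver) for pharmacokinetics, with Liver microsome (Rattus norvegicus) as the target, read by LC-MS, using microsomes, tested at 2 uM; a higher number here means faster removal of the compound, a lower number slower removal:
- Compound 1 `O=C(N[C@@H]1CCCC[C@H]1O)c1cnc(OC2CCCCC2)c(-c2ccc(Cl)cc2)c1`: 0.662 mL/min/kg
- Compound 2 `O=C(N[C@@H]1CCCC[C@H]1O)c1cnc(OCC2CC2)c(-c2ccc(Cl)cc2)c1`: 0.064 mL/min/kg
- Compound 3 `O=C(N[C@@H]1CCCC[C@H]1O)c1cnc(OCc2ccncc2)c(-c2ccc(Cl)cc2)c1`: 0.118 mL/min/kg

Two steps place compound 3: a 1.8-fold higher number from compound 2 to compound 3 (0.27 log units; within the scatter), and a 5.6-fold lower number from compound 1 to compound 3 (0.75 log units; beyond the scatter). Compound 4 `O=C(N[C@@H]1CCCC[C@H]1O)c1cnc(OCc2ccccn2)c(-c2ccc(Cl)cc2)c1` remains unmeasured. It differs at one place: pyridin-2-yl in place of pyridin-4-yl on a saturated chain carbon bound to an oxygen on an aromatic ring.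

Within the data shown here, no measured step exchanges one pyridinyl group for another. The closest evidence is the change at that same place, a 1.8-fold higher number from compound 2 to compound 3 (0.27 log units; within the scatter). The larger 10-fold lower number from compound 1 to compound 2 (1.01 log units; beyond the scatter) involves removing cyclohexyl, which this change does not do. No shift beyond the scatter is therefore expected in this assay, and no direction is favoured. The expected step is a 1.0-fold higher number from compound 3 to compound 4 (0.01 log units; within the scatter). For compound 4 the estimate is 0.12 mL/min/kg, with an expected range from 0.05 mL/min/kg to 0.3 mL/min/kg.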

Compound 4, clearance: 0.044 mL/min/kg
Compound 4: the middle estimate sits 2.7-fold (0.44 log units) above what was measured; the whole stated range lies above it.
By their numbers in this assay, from the lowest: compounds 4, 2 and 3 (each within the scatter of the next, the first and the last beyond it); then compound 1.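

In this assay, pyridin-2-yl in place of pyridin-4-yl, the same atoms joined differently, gives a 2.7-fold lower number from compound 3 to compound 4 (0.43 log units; beyond the scatter) and so shows that the point of attachment of the pyridinyl group alone can register at this position. With pyridin-2-yl in place of cyclopropyl, the series shows a 1.5-fold lower number from compound 2 to compound 4 (0.16 log units; within the scatter) and so stays within the scatter, while (pyridin-2-yl)methyl in place of cyclohexyl gives a 15-fold lower number from compound 1 to compound 4 (1.18 log units; beyond the scatter) as a clear separation. No measurement here accounts for the difference between the two pyridinyl groups.

Going by these compounds, whether pyridin-3-yl would fall with pyridin-2-yl or with pyridin-4-yl remains open. So does whether a plain phenyl group at this place would match either of them.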